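Isopropyl added to the phenyl ring of compound 1

The source may hold more compounds than are shown below. What is called first, only, known or untested is meant among the compounds shown, and "the series" means these compounds.

Measured compounds:
compound 1, `C#CCN1CCCC(OC(=O)Nc2ccccc2)C1`: > 100000 nM
compound 2, `O=C(Nc1ccccc1)OC1CCN(Cc2ccccc2)CC1`: > 100000 nM
compound 3, `O=C(Nc1ccccc1)OC1CCCN(Cc2ccccc2)C1`: 33300 nM

In an assay on BTI-TN-5B1-4 cells for inhibition of Amine oxidase [flavin-containing] B (Homo sapiens), read by fluorescence and Amplex Red, using microsomes, with a stated time of 15 min (on this read-out higher numbers stand for weaker inhibition and lower numbers for stronger inhibition), compound 1 gives > 100000 nM, which is a limit of the assay rather than a number. Compound 2 also sits at a limit, > 100000 nM. Compound 3 gives 33300 nM. Compound 1 therefore stands at the limit of > 100000 nM in this assay, at which 2 of the 3 values shown sit. Among the compounds with values here, the only measured step, an at least 3.0-fold lower number from compound 1 to compound 3 (0.47 log units; beyond the scatter), concerns the group on the ring amine nitrogen. Compound 4 `C#CCN1CCCC(OC(=O)Nc2ccc(C(C)C)cc2)C1` differs from compound 1 elsewhere: isopropyl in place of hydrogen on an aromatic carbon. Within the data shown here, no measured step touches that place, so neither direction nor size of the change in this assay can be read from the compounds at hand. Compound 4 is expected to give an estimated 80000 nM, in the range 15000 nM to 300000 nM. That estimate means an at least 1.2-fold lower number from compound 1 to compound 4 (0.09 log units; that floor lies within the scatter).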

Compound 4, half-maximal inhibitory concentration: 71800 nM
The estimate for compound 4 lay 1.1-fold (0.05 log units) above the measured number; the measured number falls inside the stated range.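

In this assay, isopropyl in place of hydrogen on the aromatic ring gives an at least 1.3-fold lower number from compound 1 to compound 4 (0.14 log units; that floor lies within the scatter). Compound 1 stands at a limit, not a number: the limit of > 100000 nM in this assay, at which 2 of the 4 values shown sit.

As far as these compounds go, with isopropyl at this place, the series gains a number that can be read in this assay, but the real size of the step stays unknown, and its floor shows no change beyond the scatter. Still open, from the compounds shown here alone, is whether a smaller chain, a methoxy group or a carboxylic acid at this place would lower the number further. Also open, going by these compounds, is how isopropyl would act on compound 3, which gives 33300 nM.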